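The source may report more compounds than this note shows. Statements on the series, on what has been measured and on what is new or still open speak of the compounds shown alone.

Measured so far in the series:

compound 1 `CC(NC(=O)/C=C/Oc1ccc(NC(=O)Nc2cc(C(F)(F)F)ccc2Cl)cc1)c1ccccc1` — 11900 nM
compound 2 `CNC(=O)C#Cc1ccc(NC(=O)Nc2ccc(Cl)c(C(F)(F)F)c2)cc1` — 23300 nM
compound 3 `CC(NC(=O)c1cccc(-c2ccc(NC(=O)Nc3ccc(Cl)c(C(F)(F)F)c3)cc2)c1)c1ccccc1` — 5670 nM

In a functional assay on HepG2 cells (Homo sapiens) for inhibition, read by MTT assay, with a stated time of 120 h (a lower number here means a stronger inhibitor, a higher number a weaker inhibitor), compound 2 stands at the highest of the three numbers. Compound 1 lies nearest to compound 2, with a lower number that is still within the usual scatter; compound 3 lies furthest from compound 2, with a lower number beyond the scatter. Going by the values given here, no step between compounds differing in one place is available, so no measured change can be carried over directly.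

Compound 4 `CNC(=O)/C(C)=C/c1ccc(NC(=O)Nc2ccc(Cl)c(C(F)(F)F)c2)cc1` has not yet been measured. It differs from compound 2 in one place: 2-(methylcarbamoyl)prop-1-en-1-yl in place of 2-(methylcarbamoyl)ethynyl on an aromatic carbon. Since the substituent keeps its donor and acceptor and changes only in chain length and bond type, a small step toward a lower number is expected from compound 2 to compound 4, a 1.6-fold lower number from compound 2 to compound 4 (0.19 log units; within the scatter), likely not beyond the scatter. Compound 4 is estimated at 15000 nM, with a range from 5000 nM to 45000 nM.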

Compound 4, half-maximal inhibitory concentration: 44300 nM
The estimate for compound 4 lay 3.0-fold (0.47 log units) below the measured number; the measured number falls inside the stated range.
By their numbers in this assay, from the lowest: compound 3; then compounds 1, 2 and 4 (each within the scatter of the next, the first and the last beyond it).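

In this assay, 2-(methylcarbamoyl)prop-1-en-1-yl in place of 2-(methylcarbamoyl)ethynyl gives a 1.9-fold higher number from compound 2 to compound 4 (0.28 log units; within the scatter) on an aromatic carbon para to a large group, so this pair is not separated by the assay. At this position, the triple bond can give way to a double bond in a chain that keeps its hydrogen-bond donor and acceptor, with no step beyond the scatter. No available evidence accounts for this step.

Still open, as far as these compounds go, is whether a carboxylic acid, an amine or a longer saturated chain at this position would step beyond the scatter.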